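Cytotoxicity notes on compounds 1 to 4

The compounds below may be only part of what the source reports. "The series", "measured", "known", "first", "only" and "open" are said of these compounds alone.

Values in an ADME assay on L02 cells (Homo sapiens) for cytotoxicity, read by MTT assay (on this read-out higher numbers stand for weaker inhibition and lower numbers for stronger inhibition), so far:
compound 1 `COc1ccc(/C=C/C(=O)c2ccc(OC)c3c2OC(C)(C)C=C3)cc1OCC=C(C)C` gives > 10000 nM
compound 2 `COc1ccc(/C=C/C(=O)c2ccc(OC)c3c2OC(C)(C)C=C3)cc1OC(=O)CCl` gives > 10000 nM
compound 3 `COc1ccc(/C=C/C(=O)Oc2cc(/C=C/C(=O)c3ccc(OC)c4c3OC(C)(C)C=C4)ccc2OC)cc1` gives 18000 nM

Compound 1 stands at a limit of this assay, not at a number. Compound 2 likewise reaches only a limit. Among the measured compounds shown here, compound 3 is the one compound with a number; the step from compound 1 to compound 3 is a step that the limit leaves unreadable from compound 1 to compound 3, the step from compound 2 to compound 3 is a step that the limit leaves unreadable from compound 2 to compound 3, and the step from compound 1 to compound 2 is a step that the two limits leave unreadable from compound 1 to compound 2. The position is summed up by the limit of > 10000 nM in this assay, at which 2 of the 3 values shown sit.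

Compound 4 `COc1ccc(/C=C/C(=O)c2ccc(OC)c3c2OC(C)(C)C=C3)cc1OS(=O)(=O)Cc1ccccc1` is still to be measured. Its change from compound 1 reads (benzylsulfonyl in place of 3-methylbut-2-en-1-yl on an oxygen on an aromatic ring). The measured steps at that oxygen bear on it but are not readable in size, so no direction beyond the scatter is expected. The step from compound 1 to compound 4 is expected to be a step that the limit leaves unreadable from compound 1 to compound 4. Compound 4 is expected at 15000 nM, between 7000 nM and 40000 nM.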

Compound 4, half-maximal inhibitory concentration: > 10000 nM
Compound 4: a limit, no number; the forecaster's own chance of this, stated with the estimate: 60%; the middle value does not contradict the limit.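

Compound 4 reaches only a limit, so no step from it to compound 1, compound 2 or compound 3 can be read: the limit of > 10000 nM in this assay, at which 3 of the 4 values shown sit.

The compounds shown leave open whether the benzylsulfonyl, 3-methylbut-2-en-1-yl and (chloromethyl)carbonyl groups differ at all in cytotoxicity.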